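The source may hold more compounds than are shown below. What is called first, only, known or untested is meant among the compounds shown, and "the series" means these compounds.

Measured so far in a functional assay on KB cells (Homo sapiens) for cytotoxicity, read by MTT assay, with a stated time of 72 h; a higher number here means a weaker inhibitor, a lower number a stronger inhibitor:
compound 1 `Cc1ccc2cc3c(nc2c1)-c1nc2ccccc2n1C3` gives 75000 nM;
compound 2 `Cc1ccc2nc3c(cc2c1)Cn1c-3nc2ccccc21` gives 11300 nM;
compound 3 `COc1ccc2cc3c(nc2c1)-c1nc2ccccc2n1C3` gives 40600 nM.

Compound 1 and compound 2 are built from the same atoms joined differently; the difference between the two cores is not broken down here. Compound 2 gives the lowest number of the three, and its gaps to compound 3 and to compound 1 lie beyond the scatter. Compound 3 differs from compound 1 by methoxy in place of methyl on an aromatic carbon, and in this assay this gave a 1.8-fold lower number from compound 1 to compound 3 (0.27 log units; within the scatter). Compound 4 `COc1ccc2nc3c(cc2c1)Cn1c-3nc2ccccc21` differs from compound 2 by the same change, (methoxy in place of methyl on an aromatic carbon). Among the measured compounds shown here, the expected step in this assay is a 1.6-fold lower number from compound 2 to compound 4 (0.21 log units; within the scatter), resting on the one measured step of a 1.8-fold lower number from compound 1 to compound 3 (0.27 log units; within the scatter), which stayed within the scatter, so compound 4 is expected to remain close to compound 2. Compound 4 is estimated at 7000 nM, with a range from 3000 nM to 18000 nM.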

Compound 4, half-maximal inhibitory concentration: 20000 nM
Estimate against measurement, compound 4: 2.9-fold (0.46 log units) below; measured number above the stated range.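

In this assay, methoxy in place of methyl on an aromatic carbon gives a 1.8-fold higher number from compound 2 to compound 4 (0.25 log units; within the scatter). Set beside the same change on the core of compound 1, the result shows that the step does not carry over as one fixed step from core to core, since the two steps run in opposite directions by more than the scatter allows: the same change on two cores in this assay, a 1.8-fold lower number (0.27 log units; within the scatter) from compound 1 to compound 3 and a 1.8-fold higher number (0.25 log units; within the scatter) from compound 2 to compound 4, 3.3-fold (0.51 log units) apart, beyond the scatter of two such steps
Each step alone stays within the scatter and rests on a single pair, so the comparison does not show a general rule for either core, or why the cores differ.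

The compounds shown carry only methyl and methoxy at this place. Open, as far as these compounds go, is how an amine, a carboxylic acid or a longer chain there would read in this assay on either core.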